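Amide for Trifluoromethyl: A Solubility Step Without a Floor

A few compounds are considered here, and "the series" means these few. Any claim that something is new, unique, unknown or untested is made for them only; others in the source may bear on it.

Measured so far:
compound 1, `COC(=O)c1ccc(-c2cnc(N)c(-c3ccc(C(F)(F)F)cc3)n2)cc1`: < 5000 nM
compound 2, `NC(=O)c1ccc(-c2cnc(N)c(-c3ccc(C(F)(F)F)cc3)n2)cc1`: < 5000 nM

In a physicochemical assay for solubility, read by HPLC, using the shake flask method, in phosphate buffer, with a stated time of 2 h, at pH 6.5 (a lower number here means a less soluble compound, a higher number a more soluble compound), compound 1 gives < 5000 nM, which is a limit of the assay rather than a number. Compound 2 gives < 5000 nM in this assay, again a limit. Going by the values given here, the one step between them, a step that the two limits leave unreadable from compound 1 to compound 2, cannot be read, since the limit of < 5000 nM in this assay, at which 2 of the 2 values shown sit: neither compound yields a number from which a change could be measured.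

Compound 3, `CNC(=O)c1ccc(-c2nc(-c3ccc(C(N)=O)cc3)cnc2N)cc1`, carries methylcarbamoyl in place of trifluoromethyl on an aromatic carbon. No measured step bears on this change; the only step shown concerns amino in place of methoxy on a carbonyl carbon, and its size is not readable. Compound 2 stands at the limit in this assay, so there is no floor from which a step could be counted, and the expected step of an at least 1.2-fold higher number from compound 2 to compound 3 (0.07 log units; that floor lies within the scatter) from compound 2 to compound 3 therefore rests on no measured evidence and is given only as a wide estimate. Compound 3 is estimated to reach 6000 nM in this assay, with a range from 1000 nM to 40000 nM.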

Compound 3, solubility: 178000 nM
Estimate against measurement, compound 3: 30-fold (1.47 log units) below; measured number above the stated range.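

In this assay, going by these compounds alone, methylcarbamoyl in place of trifluoromethyl on an aromatic carbon, para to a large group, gives an at least 35-fold higher number from compound 2 to compound 3 (1.55 log units; beyond the scatter), and this is the first step that can be read at all. The exchange keeps the heavy-atom count of the group the same, while the entering methylcarbamoyl brings a hydrogen-bond donor and a hydrogen-bond acceptor where trifluoromethyl has neither, and compound 3 is the only compound shown that yields a number rather than a limit. The value of compound 2 is a limit of the assay, so the step printed is a floor with no measured upper end: the limit of < 5000 nM in this assay, at which 2 of the 3 values shown sit.

The step between the methyl ester of compound 1 and the primary amide of compound 2 still cannot be read, so nothing shown says how that carbonyl substituent acts on the number. Going by these compounds, how much of the large step rests on the amide hydrogen also stays open, as does how a dimethylcarbamoyl group or a carboxylic acid at this same position would read in this assay.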